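From 2-ethyl-1H-imidazol-1-yl to 1H-pyrazol-1-yl

The source may report more compounds than this note shows. Statements on the series, on what has been measured and on what is new or still open speak of the compounds shown alone.

For the measured compounds named here, in a functional assay on HUVEC cells (Homo sapiens), read by scintillation counting and thymidine incorporation, with a stated time of 24 h (a lower number here means a stronger inhibitor, a higher number a weaker inhibitor), compound 2 (`CCc1nccn1C[C@@]1(c2ccc(Cl)cc2Cl)OC[C@@H](COc2ccc(N3CCN(c4ccc(-n5cnn(C(C)CC)c5=O)cc4)CC3)cc2)O1`) gives 224 nM and sits within the scatter of compound 1 (`CCC(C)n1ncn(-c2ccc(N3CCN(c4ccc(OC[C@@H]5CO[C@@](CC)(c6ccc(Cl)cc6Cl)O5)cc4)CC3)cc2)c1=O`) at 353 nM in the only comparison available. That step (a 1.6-fold lower number from compound 1 to compound 2 (0.20 log units; within the scatter)) put 2-ethyl-1H-imidazol-1-yl in place of methyl on a saturated chain carbon bound to a saturated ring carbon. Compound 3 (`CCC(C)n1ncn(-c2ccc(N3CCN(c4ccc(OC[C@@H]5CO[C@@](Cn6cccn6)(c6ccc(Cl)cc6Cl)O5)cc4)CC3)cc2)c1=O`) carries 1H-pyrazol-1-yl in place of 2-ethyl-1H-imidazol-1-yl at that carbon (1H-pyrazol-1-yl in place of 2-ethyl-1H-imidazol-1-yl on a saturated chain carbon bound to a saturated ring carbon). Going by the values given here, with one step inside the scatter as the only guide, no step beyond the scatter is expected in this assay here. The expected change (a 1.3-fold higher number from compound 2 to compound 3 (0.13 log units; within the scatter)) is an estimate resting on little. Compound 3 is estimated at 300 nM (range 120 nM to 750 nM) in this measurement.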

Compound 3, half-maximal inhibitory concentration: 307 nM
The estimate for compound 3 lay 1.0-fold (0.01 log units) below the measured number, and the stated range covers the measured number.
By their numbers in this assay, from the lowest: compounds 2, 3 and 1 (each within the scatter of the next).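

In this assay, 1H-pyrazol-1-yl in place of the larger 2-ethyl-1H-imidazol-1-yl on a saturated chain carbon bound to a saturated ring carbon gives a 1.4-fold higher number from compound 2 to compound 3 (0.14 log units; within the scatter) and the same group in place of methyl gives a 1.1-fold lower number from compound 1 to compound 3 (0.06 log units; within the scatter) as the second reading. Three groups at this carbon, two of them five-membered aromatic rings and one without a ring, thus all lie within the scatter of one another, so neither the ring nor its ethyl shows an effect here. No measurement offers a reason for this. As far as these compounds go, whether an amine, a carboxylic acid or a longer chain at this carbon would move the number beyond the scatter stays open.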